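Para-chloro on the phenyl of compound 3: stability outlook

The source may hold more compounds than are shown below. What is called first, only, known or untested is meant among the compounds shown, and "the series" means these compounds.

Compound 1 `CC(C)[C@H]1Cc2n[nH]cc2[C@@H](C(C)C)N1S(=O)(=O)c1ccc(C(F)(F)F)cc1` gives 32% in an ADME assay on microsomes from liver (Homo sapiens) for metabolic stability, with a stated time of 30 min, in the presence of a further agent that is not named here; on this read-out lower numbers stand for a less stable compound and higher numbers for a more stable compound.
Compound 2 `O=S(=O)(c1ccc(Cl)cc1)N1Cc2c[nH]nc2CC1c1cncnc1` gives 70% in this assay.
Compound 3 `O=S(=O)(c1ccc(Cl)cc1)N1Cc2c[nH]nc2CC1c1ccccc1` gives 8% in this assay.

Compound 3 stands lowest of the three numbers in this assay; compound 1 is the nearest to it, and the distance between them lies beyond the scatter, while compound 2 is the furthest. Among the compounds with values here, the one step measured in a single place, a number 62 percentage points lower from compound 2 to compound 3 (beyond the scatter), is large and shows the phenyl on the saturated ring carbon in a much less stable compound than the pyrimidin-5-yl.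

Compound 4 `O=S(=O)(c1ccc(Cl)cc1)N1Cc2c[nH]nc2CC1c1ccc(Cl)cc1` differs from compound 3 by chloro in place of hydrogen on an aromatic carbon, sitting para to a large group. Within the data shown here, no measured step shows chloro in place of hydrogen on an aromatic carbon, so nothing here bears directly on this change; the only measured step concerns a different ring exchange. Compound 4 is therefore expected to stay close to compound 3, with a number 4 percentage points higher from compound 3 to compound 4 (within the scatter) not beyond the scatter. The estimate for compound 4 in this assay is 12%, within 3% to 30%.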

Compound 4, percent of the compound remaining: 33%
Compound 4: middle estimate off by 21 percentage points, on the low side, and the stated range ends below it.
By their numbers in this assay, from the lowest: compound 3; then compounds 1 and 4 (each within the scatter of the next); then compound 2.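

Chloro in place of hydrogen on this aromatic carbon, para to a large group, goes with a number 25 percentage points higher from compound 3 to compound 4 (beyond the scatter) in this assay, the first sign that this place on the phenyl ring matters for the read-out and that a single chlorine can change it beyond the scatter. The exchange on the saturated ring carbon still counts, since 4-chlorophenyl in place of pyrimidin-5-yl goes with a number 37 percentage points lower from compound 2 to compound 4 (beyond the scatter), a smaller drop than a number 62 percentage points lower from compound 2 to compound 3 (beyond the scatter) seen for the unsubstituted phenyl, so the chloro closes part of the gap to the pyrimidin-5-yl but not all of it. Nothing measured alongside these numbers accounts for the shift, and the reason for it stays unknown.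

The compounds shown leave open whether this rise is particular to chloro or would also appear with fluoro, a methoxy group, a nitrile or an amine at the same place on the phenyl ring. They also leave open whether chloro on another carbon of that ring would go with a comparable step, or with none at all.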